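This account rests on a few compounds, and the source may have more. Where it says the series, first, only, none or still open, it means among the compounds named here.

Compound 1 `COc1cccc(/C=C/c2ccc(S(N)(=O)=O)cc2)c1` gives 30700 nM
Compound 2 `NS(=O)(=O)c1ccc(/C=C/c2ccc(F)cc2)cc1` gives 26700 nM

Both values come from a functional assay on LOX IMVI cells (Homo sapiens) for inhibition (on this read-out lower numbers stand for stronger inhibition of growth and higher numbers for weaker inhibition of growth), and compound 2 stands within the usual scatter of compound 1, so the two cannot be told apart. Compound 3 `CN(C)c1ccc(/C=C/c2ccc(S(N)(=O)=O)cc2)cc1` has dimethylamino in place of fluoro on an aromatic carbon and keeps the rest of compound 2. For the measured compounds named here, no measured pair shows what a single change does here, so any forecast is uncertain. A modest fall in the number, meaning stronger inhibition of growth, is expected, though no change beyond the scatter remains possible. The expected move is a 2.1-fold lower number from compound 2 to compound 3 (0.31 log units; beyond the scatter) in this estimate. For compound 3 the estimate is 13000 nM with an expected range from 3000 nM to 40000 nM in this assay.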

Compound 3, concentration for 50% growth inhibition: 18700 nM
The estimate for compound 3 lay 1.4-fold (0.16 log units) below the measured number; the measured number falls inside the stated range.
By their numbers in this assay, from the lowest: compounds 3, 2 and 1 (each within the scatter of the next).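

In this assay, for the compounds shown here, the single change of dimethylamino in place of fluoro gives a 1.4-fold lower number from compound 2 to compound 3 (0.15 log units; within the scatter) and this step lies within the usual scatter. On this aromatic carbon para to a large group, the larger dimethylamino, which adds a hydrogen-bond acceptor, therefore cannot be told apart from fluoro. No measurement here explains this result. Going by these compounds, whether a carboxylic acid or a longer chain at this position would move the number beyond the scatter stays open. So does whether the same change would behave alike in other cell lines.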